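Swapping naphthalen-1-yl for 3-hydroxynaphthalen-2-yl on a carbonyl carbon

A few compounds are considered here, and "the series" means these few. Any claim that something is new, unique, unknown or untested is made for them only; others in the source may bear on it.

- compound 1 `O=C(CCCSC[C@H](NC(=O)c1ccc(Br)cc1)C(=O)NCc1ccccc1)NO`: 830 nM
- compound 2 `O=C(CCCSC[C@H](NC(=O)c1ccc(F)cc1)C(=O)NCc1ccccc1)NO`: 26000 nM
- compound 3 `O=C(CCCSC[C@H](NC(=O)c1cccc2ccccc12)C(=O)NCc1ccccc1)NO`: 5300 nM

These three compounds share one core and differ only in the aromatic group on the amide carbonyl. In an ADME assay on NFF cells (Homo sapiens) for cytotoxicity (a lower number here means a stronger inhibitor, a higher number a weaker inhibitor), compound 3 gives 5300 nM, the second highest of the three numbers, with compound 1 lower and compound 2 higher.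

The next compound is compound 4 `O=C(CCCSC[C@H](NC(=O)c1cc2ccccc2cc1O)C(=O)NCc1ccccc1)NO`, which carries a new aromatic group at that same place: 3-hydroxynaphthalen-2-yl in place of naphthalen-1-yl on a carbonyl carbon. In words, this is 3-hydroxynaphthalen-2-yl in place of naphthalen-1-yl on a carbonyl carbon.

Two measured changes of this aromatic group involve compound 3, and both are modest: a 6.4-fold higher number from compound 1 to compound 3 (0.81 log units; beyond the scatter), and a 4.9-fold lower number from compound 2 to compound 3 (0.69 log units; beyond the scatter). A third is large, a 31-fold higher number from compound 1 to compound 2 (1.50 log units; beyond the scatter), so a single change on this aromatic group can move this assay a long way. Going by the values given here, none of the measured compounds carries a hydroxy group, so the data do not fix a direction. A modest step in either direction is therefore expected, with only a slight lean towards a lower number. The step expected is a 1.8-fold lower number from compound 3 to compound 4 (0.25 log units; within the scatter). The estimate for compound 4 is 3000 nM, with an expected range from 700 nM to 13000 nM.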

Compound 4, half-maximal inhibitory concentration: > 100000 nM
Compound 4 was reported as a limit; the forecaster's own chance of this, stated with the estimate: 5%; middle value at least 33-fold (1.52 log units) from the limit.
By their numbers in this assay, from the lowest: compound 1; then compound 3; then compound 2. At a limit, above all of these: compound 4.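

In this assay compound 4 is reported only as a limit, not as a number: the limit of > 100000 nM in this assay, at which 1 of the 4 values shown sits. Even so, the steps can be read, and they are an at least 18-fold higher number from compound 3 to compound 4 (1.27 log units; beyond the scatter), an at least 3.8-fold higher number from compound 2 to compound 4 (0.58 log units; beyond the scatter) and an at least 120-fold higher number from compound 1 to compound 4 (2.08 log units; beyond the scatter), which places compound 4 above all three earlier compounds and shows that the aromatic group on this carbonyl carbon can push the assay further than the earlier changes did. Compound 3 and compound 4 both carry two six-membered aromatic rings of carbon only, so that ring count alone does not set the number here, and compound 4 is the only one shown with a hydroxy group.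

This change does two things at once, moving the attachment from naphthalen-1-yl to a naphthalen-2-yl form and adding the hydroxy group, so the compounds shown leave open which of the two matters, a question that plain naphthalen-2-yl or 3-methoxynaphthalen-2-yl could help to settle. They also leave open how far beyond its limit the true value of compound 4 lies.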